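This account rests on a few compounds, and the source may have more. Where it says the series, first, only, none or still open, it means among the compounds named here.

Working notes on the series. In a functional assay on LOX IMVI cells (Homo sapiens) for cytotoxicity, read by MTT assay, with a stated time of 24 h (a higher number here means a weaker inhibitor, a lower number a stronger inhibitor), compound 1 `COc1cc(-c2nc(-c3ccccc3)[nH]c2-c2ccnc(NCCCNS(=O)(=O)c3ccccc3)n2)ccc1Cl` gives 7470 nM, compound 2 `COc1cc(-c2nc(-c3ccccc3)[nH]c2-c2ccnc(NCCCNS(=O)(=O)c3ccc(Cl)cc3)n2)ccc1Cl` gives 60900 nM, and compound 3 `COc1cc(-c2nc(-c3ccccc3)[nH]c2-c2ccnc(NCCCNS(=O)(=O)c3ccc(F)cc3)n2)ccc1Cl` gives 4530 nM. Compound 3 thus sits with compound 1 at the low end of these numbers: a 1.6-fold lower number from compound 1 to compound 3 (0.22 log units; within the scatter) stays within the scatter, while a 13-fold lower number from compound 2 to compound 3 (1.13 log units; beyond the scatter) clearly separates it from compound 2.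

Compound 4 `COc1cc(-c2nc(-c3ccccc3)[nH]c2-c2ccnc(NCCCNS(=O)(=O)c3ccc(C(F)(F)F)cc3)n2)ccc1Cl` carries trifluoromethyl in place of fluoro on an aromatic carbon, para to a large group: trifluoromethyl in place of fluoro on an aromatic carbon. Trifluoromethyl has not yet been measured at this place, so the nearest evidence is the two other substituents there. Fluoro in compound 3 hardly moved the number, whereas chloro in compound 2 gave an 8.2-fold higher number from compound 1 to compound 2 (0.91 log units; beyond the scatter). With only these two cases the direction is uncertain, but a modest rise is expected, short of the full height of compound 2. The expected change is a 3.3-fold higher number from compound 3 to compound 4 (0.52 log units; beyond the scatter). For compound 4 the estimated value is 15000 nM, with an expected range of 4000 nM to 60000 nM.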

Compound 4, half-maximal inhibitory concentration: 1780 nM
Compound 4: the middle estimate sits 8.4-fold (0.93 log units) above what was measured; measured number below the stated range.
By their numbers in this assay, from the lowest: compound 4; then compounds 3 and 1 (each within the scatter of the next); then compound 2.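

In this assay, for the compounds shown here, trifluoromethyl is the first group at this place, para to a large group, to separate from hydrogen towards a lower number, with a 4.2-fold lower number from compound 1 to compound 4 (0.62 log units; beyond the scatter), whereas fluoro stayed within the scatter of hydrogen and chloro moved the number upward. The other two comparisons, a 2.5-fold lower number from compound 3 to compound 4 (0.41 log units; beyond the scatter) and a 34-fold lower number from compound 2 to compound 4 (1.53 log units; beyond the scatter), leave compound 4 lowest of the four, so the substituents at this place do not move the number in a single direction from hydrogen. No measurement shown here bears on why chloro and trifluoromethyl move the number in opposite directions.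

From the compounds shown here alone, whether other groups at this place, such as a nitrile, a methoxy or a carboxylic acid, also give lower numbers remains open. Also open, going by these compounds, is whether the trifluoromethyl step holds with a longer chain in place of the present linker.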